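Half-life notes: from compound 2 to compound 3

The source may report more compounds than this note shows. Statements on the series, on what has been measured and on what is new or still open speak of the compounds shown alone.

In an ADME assay on microsomes from liver (Rattus norvegicus) for metabolic stability (on this read-out higher numbers stand for a longer-lived compound and lower numbers for a shorter-lived compound), compound 1 `CC(C)C(Cc1ncc[nH]1)c1ccc(-c2ccc3cccc(F)c3c2)[nH]c1=O` gives < 0.0667 h, which is a limit of the assay and not a number. Among the compounds with values here, compound 2 `CC(C)C(Nc1nnc[nH]1)c1ccc(-c2ccc3cccc(F)c3c2)[nH]c1=O` gives 1.29 h, the only actual number so far, so its standing rests on a single comparison.

Compound 3 `CC(C)C(c1ncco1)c1ccc(-c2ccc3cccc(F)c3c2)[nH]c1=O` differs from compound 2 as follows: 1,3-oxazol-2-yl in place of (4H-1,2,4-triazol-3-yl)amino on a saturated chain carbon bound to an aromatic carbon and a saturated chain carbon. In words, 1,3-oxazol-2-yl stands in place of (4H-1,2,4-triazol-3-yl)amino on a saturated chain carbon bound to an aromatic carbon and a saturated chain carbon.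

Within the data shown here, one measured step bears on this change, as it falls at the same place: an at least 19-fold higher number from compound 1 to compound 2 (1.28 log units; beyond the scatter). That step is large and beyond the scatter, but it is bounded by a limit, and the group in compound 3 matches neither group in it. Like compound 1, compound 3 has no amino group at this place, so a move towards compound 1 is the working expectation, though not a full one. A shorter half-life in this assay is expected, with an estimated step of a 4.3-fold lower number from compound 2 to compound 3 (0.63 log units; beyond the scatter). Compound 3 is estimated at 0.3 h, with an expected range of 0.08 h to 1.1 h.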

Compound 3, half-life: 0.0983 h
Compound 3: the middle estimate sits 3.1-fold (0.48 log units) above what was measured; measured number inside the range.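

At the saturated chain carbon bound to an aromatic carbon and a saturated chain carbon, this assay now gives a 13-fold lower number from compound 2 to compound 3 (1.12 log units; beyond the scatter), so among the three compounds the longer half-life stays with the (4H-1,2,4-triazol-3-yl)amino group of compound 2 alone. The 1,3-oxazol-2-yl group does not bring compound 3 clearly away from compound 1, with an at least 1.4-fold higher number from compound 1 to compound 3 (0.16 log units; that floor lies within the scatter), a floor within the scatter that supports no order between the two. Compound 1 gives a limit of the assay and not a number, which leaves the true size of that comparison unfixed: the limit of < 0.0667 h in this assay, at which 1 of the 3 values shown sits.

The compounds shown do not separate the contribution of the amino link from that of the triazole ring, since the two change together in every step at this place, and a (1H-imidazol-2-yl)amino group on the same carbon would pull them apart. On these data alone, how a group without a ring fares here, such as a plain amine or a carboxylic acid, also stays open.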